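This account rests on a few compounds, and the source may have more. Where it says the series, first, only, none or still open, it means among the compounds named here.

Compound 1 `c1ccc(-c2nn(-c3ccccc3)cc2-c2nc3ccccc3[nH]2)cc1`: > 50000 nM
Compound 2 `Cc1ccc2[nH]c(-c3cn(-c4ccccc4)nc3-c3ccccc3)nc2c1`: > 50000 nM
Compound 3 `COc1ccc2[nH]c(-c3cn(-c4ccccc4)nc3-c3ccccc3)nc2c1`: > 50000 nM

In an ADME assay on HaCaT cells (Homo sapiens) for cytotoxicity, read by MTT assay, with a stated time of 48 h (on this read-out lower numbers stand for stronger inhibition and higher numbers for weaker inhibition), none of these compounds has a number, and all three rest on one value: the limit of > 50000 nM in this assay, at which 3 of the 3 values shown sit. Compound 3 therefore stands at a limit, > 50000 nM, and not at a measured potency.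

Compound 4 `FC(F)(F)c1ccc2[nH]c(-c3cn(-c4ccccc4)nc3-c3ccccc3)nc2c1` has trifluoromethyl in place of methoxy on an aromatic carbon. Going by the values given here, three measured steps bear on this change: a step that the two limits leave unreadable from compound 1 to compound 2, a step that the two limits leave unreadable from compound 1 to compound 3 and a step that the two limits leave unreadable from compound 2 to compound 3. None of them gives a size to carry over, so no clear shift in either direction is expected. The expected change is a step that the limit leaves unreadable from compound 3 to compound 4. Compound 4 is estimated at 60000 nM, within an expected range of 30000 nM to 120000 nM.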

Compound 4, half-maximal inhibitory concentration: 37200 nM
Compound 4: the middle estimate sits 1.6-fold (0.21 log units) above what was measured, and the stated range covers the measured number.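

In this assay, going by these compounds alone, compound 4, with trifluoromethyl on this aromatic carbon, is the only compound with a measured number rather than a limit, and the other compounds rest on one value: the limit of > 50000 nM in this assay, at which 3 of the 4 values shown sit. The limits still allow only floors for its steps: an at least 1.3-fold lower number from compound 3 to compound 4 (0.12 log units; that floor lies within the scatter), an at least 1.3-fold lower number from compound 2 to compound 4 (0.12 log units; that floor lies within the scatter) and an at least 1.3-fold lower number from compound 1 to compound 4 (0.12 log units; that floor lies within the scatter). As far as these compounds go, their true sizes remain unknown, and the steps among compound 1, compound 2 and compound 3 cannot be read.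

From the compounds shown here alone, it remains open whether the number for compound 4 truly differs from those of the other compounds. Going by these compounds, it is also open whether an amine or a carboxylic acid at this position would give a measured number.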